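The source may hold more compounds than are shown below. What is called first, only, known or untested is meant among the compounds shown, and "the series" means these compounds.

Measured so far:

Compound 1, `CCn1nc(Cc2ccc(SC)cc2)c2ccccc2c1=O`: > 100000 nM in a functional assay on aorta with Alpha-1D adrenergic receptor (Rattus norvegicus) as the target; a higher number here means that more compound is needed for the effect, a lower number that less compound is needed
Compound 2, `C=CCn1nc(Cc2ccc(SC)cc2)c2ccccc2c1=O`: > 100000 nM in this assay
Compound 3, `CCn1nc(Cc2ccc(OC)c(OC)c2)c2ccccc2c1=O`: 5300 nM in this assay

Compound 1 gives > 100000 nM in this assay, which is a limit of the assay and not a number. Compound 2 likewise gives > 100000 nM in this assay, again a limit and not a number. The change between them is vinyl in place of methyl on a saturated chain carbon bound to an aromatic nitrogen. Its size is a step that the two limits leave unreadable from compound 1 to compound 2; the two values rest on (the limit of > 100000 nM in this assay, at which 2 of the 3 values shown sit), so the step cannot be read. Among the compounds with values here, compound 3 is the only compound of the three with a number in this assay, at 5300 nM. How the core of compound 3 differs from that of compound 1 is not broken down here.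

Compound 4, `C=CCn1nc(Cc2ccc(OC)c(OC)c2)c2ccccc2c1=O`, has not yet been measured. It stands to compound 3 as compound 2 stands to compound 1: the change is vinyl in place of methyl on a saturated chain carbon bound to an aromatic nitrogen, the same change at the same place. The measured pair gives no readable size for it, so the expectation for compound 4 can rest on nothing more than the value of compound 3 at 5300 nM and the small size of the change, which adds one carbon and one double bond outside aromatic rings. The expected step is no change at the digits printed from compound 3 to compound 4 (within the scatter), that is, little movement either way. Compound 4 is therefore estimated at 5300 nM in this assay, with a range from 1800 nM to 16000 nM.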

Compound 4, half-maximal effective concentration: 9800 nM
Estimate against measurement, compound 4: 1.8-fold (0.27 log units) below; measured number inside the range.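

On the core of compound 3, vinyl in place of methyl on a saturated chain carbon bound to an aromatic nitrogen (the same difference read as ethyl to allyl) gives a 1.8-fold higher number from compound 3 to compound 4 (0.27 log units; within the scatter) in this assay, so compound 3 and compound 4 cannot be told apart in this read-out. On the core of compound 1 the same change cannot be read, so the series offers no second size to set against this one: the limit of > 100000 nM in this assay, at which 2 of the 4 values shown sit. The change is therefore tolerated on the core of compound 3 within the scatter, but a single readable pair does not show that this result carries to another core, and the pair of compound 1 and compound 2 neither supports nor contradicts it.

Still open, from the compounds shown here alone, is whether a longer chain such as butyl, an amine or a carboxylic acid in place of the vinyl would give a step beyond the scatter on the core of compound 3. Also open, going by these compounds, is how the same change behaves on any core where both partners give numbers rather than limits, which is what a real test of carrying it across cores would need.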